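Glycinamide series: amino-acid ester variation, oral tail flick

This account rests on a few compounds, and the source may have more. Where it says the series, first, only, none or still open, it means among the compounds named here.

Three compounds of the series have numbers in a functional assay on the whole organism (Tail, strain ICR) with Mus musculus as the target, in the tail flick test, with a stated time of 90 min, at a dose of 25 umol/kg by the oral route; on this read-out lower numbers stand for a weaker effect and higher numbers for a stronger effect at the one dose given. Compound 1 `O=C(OCc1ccccc1)[C@@H]1CCCN1C(=O)CN(c1nc(Cl)nc2[nH]cnc12)C1CC1` gives 43.3%. Compound 3 `CC(C)[C@H](NC(=O)CN(c1nc(Cl)nc2[nH]cnc12)C1CC1)C(=O)OCc1ccccc1` gives 51.3%. Compound 2 `CC(C)[C@H](NC(=O)CN(c1ncnc2c1ncn2C1CCCCO1)C1CC1)C(=O)OCc1ccccc1` gives 30.1%, the lowest of the three numbers; the gap to compound 1 and the larger gap to compound 3 both lie beyond the usual scatter of this read-out. Among the measured compounds shown here, no two measured compounds differ in a single place, so no step within the measured set can be isolated.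

Compound 4 `O=C(CN(c1ncnc2c1ncn2C1CCCCO1)C1CC1)N[C@@H](CC(=O)OCc1ccccc1)C(=O)OCc1ccccc1` is not yet measured. It differs from compound 2 in one place: (benzyloxycarbonyl)methyl in place of isopropyl on a saturated chain carbon bound to an amide-type nitrogen and a carbonyl carbon. Nothing measured here speaks to this kind of replacement, so the expectation rests only on the starting number. The expected step is small, likely none beyond the scatter, in either direction: a number 2.1 percentage points lower from compound 2 to compound 4 (within the scatter). Compound 4 is expected to give about 28% in this assay, within a range from 12% to 48%. This rests on the number of compound 2, 30.1%, with nothing measured indicating a gain.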

Compound 4, a percentage reported as activity, at one dose (the size of the read-out at that dose, not a potency): 25.1%
Compound 4: the middle estimate sits 2.9 percentage points above what was measured, within the range that was stated.
By their numbers in this assay, from the lowest: compounds 4 and 2 (each within the scatter of the next); then compounds 1 and 3 (each within the scatter of the next).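

Among the compounds shown here, at this position, on a saturated chain carbon bound to an amide-type nitrogen and a carbonyl carbon, (benzyloxycarbonyl)methyl in place of isopropyl gives, in this assay, a number 5 percentage points lower from compound 2 to compound 4 (within the scatter) for the first step that isolates one place. The position therefore takes a group of 11 heavy atoms with a six-membered aromatic ring and 2 hydrogen-bond acceptors, in place of one of 3 heavy atoms, without a change that can be told from the scatter. Nothing measured explains why the step stays this small.

Open, as far as these compounds go, is whether a carboxylic acid in place of the benzyl ester of this side chain, or an aminobutyl chain at the same carbon, would leave the number as unchanged. Also open, from the compounds shown here alone, is whether the same replacement would read alike on the core of compound 3.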